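This account rests on a few compounds, and the source may have more. Where it says the series, first, only, none or still open, it means among the compounds named here.

Measured compounds:

Compound 1, `COc1ccc(Sc2cn(-c3ccc4c(c3)B(O)OC4)c3ccccc23)cc1`, gives > 10 ug/mL.
Compound 2, `O=C(NC1CCCCC1)c1cccn1-c1ccc2c(c1)B(O)OC2`, gives > 10 ug/mL.
Compound 3, `O=C(c1ccc(Cl)cc1)c1ccn(-c2ccc3c(c2)B(O)OC3)c1`, gives > 10 ug/mL.

All three numbers come from an ADME assay on L929 cells (Mus musculus) for cytotoxicity, read by resazurin assay, with a stated time of 72 h; a higher number here means a weaker inhibitor, a lower number a stronger inhibitor. The result for compound 1 is a limit of the assay, not a measured number. The same holds for compound 2, whose result is a limit as well. Compound 3 also stands at a limit: its reading marks the point up to which the assay was run, so its true value is not known, only that it lies past that point. In fact (the limit of > 10 ug/mL in this assay, at which 3 of the 3 values shown sit), so compound 3 is neither separated from nor ranked against the other two.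

Compound 4, `Nc1ccc(C(=O)c2ccn(-c3ccc4c(c3)B(O)OC4)c2)cc1`, differs from compound 3 in one place: amino in place of chloro on an aromatic carbon. Going by the values given here, no measured pair shows what such a swap does here, so no step in this assay can be read off for it. With compound 3 at the limit, the expectation is a change from compound 3 to compound 4 no larger than the usual scatter, expressed as a step that the limit leaves unreadable from compound 3 to compound 4. Compound 4 is therefore expected to give about 15 ug/mL, within the range from 7 ug/mL to 40 ug/mL, most likely again reported only as a limit.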

Compound 4, half-maximal inhibitory concentration: 3.9 ug/mL
Compound 4: the middle estimate sits 3.8-fold (0.59 log units) above what was measured, outside the stated range (below it).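

Compound 4 is the only compound shown whose reading in this assay is a number and not a limit, so this place, para to a large group on the six-membered aromatic ring, is one where swapping a single group can change the reading. Amino in place of chloro brings an at least 2.5-fold lower number from compound 3 to compound 4 (0.40 log units; beyond the scatter), and a lower number here means a stronger inhibitor, so the change from 4-chlorophenyl to 4-aminophenyl makes the compound more toxic to these cells. The true size of the step remains unknown because compound 3 has no exact value: the limit of > 10 ug/mL in this assay, at which 3 of the 4 values shown sit.

From the compounds shown here alone, it remains open whether another group at this place, such as hydroxyl or dimethylamino, would lower the number as amino does. Going by these compounds, it is also open whether amino would have the same effect on the cores of compound 1 or compound 2.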